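Aryl amine swap on the shared core: toward compound 4

The compounds below may be only part of what the source reports. "The series", "measured", "known", "first", "only" and "open" are said of these compounds alone.

Measured so far in a functional assay on NCI-H226 cells (Homo sapiens) for inhibition, read by MTT assay, with a stated time of 48 h, tested at 10 uM; a higher number here means more inhibition at the concentration tested (going by the name of the read-out), a lower number less inhibition:
Compound 1 `COc1ccc(F)cc1Nc1cc(NC(=O)Nc2c(Cl)cccc2Cl)ncn1` gives 31.3%.
Compound 2 `Cc1ccc(Nc2cc(NC(=O)Nc3c(Cl)cccc3Cl)ncn2)cc1C` gives 41.3%.
Compound 3 `COc1cc(NC(=O)Nc2cc(Nc3ccc(F)c(Cl)c3)ncn2)cc(OC)c1` gives 36.7%.

On these numbers compound 3 holds the nominal second place of the three, but its gaps to compound 2 and to compound 1 both lie within the usual scatter of repeated measurement, so no ranking among the three is claimed.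

Compound 4 `COc1cc(NC(=O)Nc2cc(Nc3ccc(Br)cc3OC)ncn2)cc(OC)c1` differs from compound 3 in one place: 4-bromo-2-methoxyphenyl in place of 3-chloro-4-fluorophenyl on a nitrogen on an aromatic ring. Going by the values given here, the only measured step that bears on this change is the one at the same nitrogen, which also exchanged one aryl group for another: a number 10 percentage points higher from compound 1 to compound 2 (within the scatter). That change of aryl group left the read-out essentially where it was. The present exchange is of the same kind, at the same place, and the three measured aryl variants on that nitrogen all cluster together in this assay. The step is therefore expected to be a number 0.3 percentage points higher from compound 3 to compound 4 (within the scatter), that is, no movement beyond the scatter in either direction.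

Compound 4 is accordingly estimated at 37%, with a range from 25% to 50%.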

Compound 4, a percentage reported as inhibition, at one concentration (the size of the read-out at that concentration, not a potency): 25.7%
Compound 4: middle estimate off by 11.3 percentage points, on the high side, and the stated range covers the measured number.
By their numbers in this assay, from the lowest: compounds 4, 1, 3 and 2 (each within the scatter of the next, the first and the last beyond it).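

At the nitrogen on an aromatic ring, the aryl exchange gives a number 11 percentage points lower from compound 3 to compound 4 (beyond the scatter) in this assay, whereas the earlier exchange at this place, a number 10 percentage points higher from compound 1 to compound 2 (within the scatter), did not leave the scatter. The aryl groups on this nitrogen are therefore not freely interchangeable in this assay: with the rest of compound 3 held constant, 4-bromo-2-methoxyphenyl gives a lower read-out than 3-chloro-4-fluorophenyl, though the step is modest and rests on one pair. No measurement to hand accounts for this difference.

This exchange brings in bromine and a methoxy group while removing chlorine and fluorine, so the compounds shown do not separate the contribution of each substituent, and a single pair cannot show whether the same exchange would have a similar effect alongside the other group on the far side of the shared core. Also open, from the compounds shown here alone, is how the read-out would respond to an aryl group on this nitrogen carrying a carboxylic acid or a dimethylamino group, or to a saturated ring such as cyclohexyl in place of the aryl group.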